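A few compounds are considered here, and "the series" means these few. Any claim that something is new, unique, unknown or untested is made for them only; others in the source may bear on it.

In a functional assay on MDA-MB-231 cells (Homo sapiens) for cytotoxicity, read by MTT assay, with a stated time of 48 h (on this read-out lower numbers stand for stronger inhibition and higher numbers for weaker inhibition), compound 1 `COc1ccc(OC)c(C2=NOC(COc3ccc(-c4nnnn4-c4cc(OC)c(OC)c(OC)c4)cc3N)C2)c1` gives 3500 nM. Compound 2 `COc1cc(C2=NOC(COc3ccc(-c4nnnn4-c4cc(OC)c(OC)c(OC)c4)cc3N)C2)cc(OC)c1OC` gives 3230 nM, and compound 3 `COc1cc(C2=NOC(COc3ccc(-c4nnnn4-c4cc(OC)c(OC)c(OC)c4)cc3N)C2)ccc1O` gives 3620 nM. Compound 1 therefore stands level with both, as all three numbers lie within the usual scatter of one another.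

Compound 4 `COc1ccc(F)c(C2=NOC(COc3ccc(-c4nnnn4-c4cc(OC)c(OC)c(OC)c4)cc3N)C2)c1` keeps the core of compound 1 but has fluoro in place of methoxy on an aromatic carbon, which turns 2,5-dimethoxyphenyl into 2-fluoro-5-methoxyphenyl. The closest evidence comes from other swaps on this same phenyl group. These are a 1.1-fold lower number from compound 1 to compound 2 (0.03 log units; within the scatter), a 1.0-fold higher number from compound 1 to compound 3 (0.01 log units; within the scatter) and a 1.1-fold higher number from compound 2 to compound 3 (0.05 log units; within the scatter), and all of them are small. None of these compounds carries fluoro, so the evidence is indirect and the range must stay wide. Even so, no step beyond the scatter is expected in this assay, in either direction. The estimated step is a 1.1-fold lower number from compound 1 to compound 4 (0.03 log units; within the scatter), inside the scatter. For compound 4 the estimated value is 3300 nM, with an expected range from 1400 nM to 7500 nM.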

Compound 4, half-maximal inhibitory concentration: 2830 nM
Compound 4: the middle estimate sits 1.2-fold (0.07 log units) above what was measured, within the range that was stated.
By their numbers in this assay, from the lowest: compounds 4, 2, 1 and 3 (each within the scatter of the next).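

Among these compounds, compound 4 is the first compound here to carry fluoro on this phenyl group, on an aromatic carbon ortho to a large group and para to a methoxy group, and in this assay the step for this swap is a 1.2-fold lower number from compound 1 to compound 4 (0.09 log units; within the scatter), so fluoro and methoxy cannot be told apart at this position. The comparisons with the other two phenyl groups read the same way, with a 1.3-fold lower number from compound 3 to compound 4 (0.11 log units; within the scatter) and a 1.1-fold lower number from compound 2 to compound 4 (0.06 log units; within the scatter), so all four compounds now stand level with one another in this assay. No other measurement is available that could help interpret this result.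

On these data alone, whether a much larger or charged group here, such as an amine, a carboxylic acid or a longer chain like butoxy, would move the number beyond the scatter stays open. As far as these compounds go, whether fluoro elsewhere on this phenyl group would behave the same also stays open.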